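Swapping the aryl group on a piperazine succinimide

A few compounds are considered here, and "the series" means these few. Any claim that something is new, unique, unknown or untested is made for them only; others in the source may bear on it.

Going by the values given here, compound 1 `CCC(C(=O)N1CCN(c2cccc(OC)c2)CC1)N1C(=O)CCC1=O` was tested in a functional assay on the whole organism (strain Swiss) with Mus musculus as the target, in the maximal electroshock model, with a stated time of 0.25 h, at a dose of 300 mg/kg by the intraperitoneal route (on this read-out lower numbers stand for a weaker effect and higher numbers for a stronger effect at the one dose given), where compound 1 gives 25%, the lower of the two numbers measured so far. The other measured compound, compound 2 `CC(C(=O)N1CCN(c2ccc(F)cc2)CC1)N1C(=O)CCC1=O`, gives 100% in this assay, a gap that lies beyond the usual scatter. The compound still to be measured, compound 3 `CCC(C(=O)N1CCN(c2ccc(Cl)cc2)CC1)N1C(=O)CCC1=O`, keeps the whole of compound 1 except for one change: 4-chlorophenyl in place of 3-methoxyphenyl on an amine nitrogen in a ring. Since compound 2, which carries a halogen on its phenyl ring, reaches 100%, a step upward is expected from compound 1 to compound 3, clearly larger than the scatter, giving a number 50 percentage points higher from compound 1 to compound 3 (beyond the scatter). Among the compounds with values here, on that basis compound 3 is expected to give 75% in this assay, with a likely range from 35% to 100%, the uncertainty reflecting that only two measured compounds exist to compare against.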

Compound 3, a percentage reported as activity, at one dose (the size of the read-out at that dose, not a potency): 0%
The estimate for compound 3 lay 75 percentage points above the measured number, and the stated range ends above it.
By their numbers in this assay, from the lowest: compound 3; then compound 1; then compound 2.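

In this assay, putting 4-chlorophenyl in place of 3-methoxyphenyl on the amine nitrogen in the ring gives a number 25 percentage points lower from compound 1 to compound 3 (beyond the scatter). Going by these compounds alone, this is the first one-place comparison, and it shows that the aryl group at this nitrogen matters on its own, since nothing else in the molecule changes. It also shows that a halogen on the phenyl ring does not by itself bring a strong effect, as compound 3 gives 0% at the one dose tested. Nothing available explains why this swap lowers the read-out. From the compounds shown here alone, what a plain phenyl or a benzyl group would give at this nitrogen remains open, as does whether the same swap would move the read-out similarly on the core of compound 2.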